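The source may report more compounds than this note shows. Statements on the series, on what has been measured and on what is new or still open speak of the compounds shown alone.

Measured in an assay on isolated protein for inhibition of protein kinase C zeta type (Homo sapiens), with stated times of 1 h and 2.5 min, tested at 30 uM; on this read-out lower numbers stand for less inhibition and higher numbers for more inhibition at the one concentration tested (going by the name of the read-out):

Compound 1, `CCOC(=O)c1c(-c2cccc(NC(C)=O)c2)csc1N`: 89%
Compound 2, `CCOC(=O)c1c(-c2ccc(C(F)(F)F)cc2)csc1N`: 16%

Two compounds share an ethyl ester on an aminothiophene core and differ in the aryl group attached to it. Of the two numbers in this assay, compound 1 gives the highest, at 89%; its nearest neighbour is compound 2, which stands a long way lower: compound 2 gives 16%, a gap well beyond the scatter of the measurement. Going by the values given here, since the two measured compounds differ in more than one place, no single step between them is recorded, and only the two values themselves can be compared.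

Compound 3, `CCOC(=O)c1c(-c2cccc(C#N)c2)csc1N`, has not yet been measured in this assay. It departs from compound 1 in one place: cyano in place of acetamido on an aromatic carbon. The acetamido that carries one hydrogen-bond donor is gone, and a cyano group with no donor stands on the same carbon of the ring.

Among the compounds with values here, no measured pair shows what such a change does here. On the evidence of compound 1 at 89% and compound 2 at 16%, a step downward of moderate size is expected, a number 44 percentage points lower from compound 1 to compound 3 (beyond the scatter). Compound 3 is therefore estimated at 45%, within a range from 10% to 80%.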

Compound 3, a percentage reported as inhibition, at one concentration (the size of the read-out at that concentration, not a potency): 32%
Compound 3: middle estimate off by 13 percentage points, on the high side; measured number inside the range.
By their numbers in this assay, from the lowest: compound 2; then compound 3; then compound 1.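

In this assay, going by these compounds alone, cyano in place of acetamido on an aromatic carbon gives a number 57 percentage points lower from compound 1 to compound 3 (beyond the scatter), the first step in this set that can be read at a single place, and it shows that the read-out responds to what stands on this carbon, meta to a large group, while the rest of the structure stays the same. The exchange is not a simple one: the acetamido that leaves has 4 heavy atoms and a hydrogen-bond donor, the cyano that enters has 2 heavy atoms and no donor, and both have a hydrogen-bond acceptor, so this one step cannot assign the loss to any one of these differences. No measurement offered here explains the fall in the number.

The compounds shown leave open whether an amine or a longer chain such as propionamido on the same carbon would keep the higher number of compound 1 or fall towards that of compound 3. They also leave open whether the same step would appear with a carboxylic acid in place of the ethyl ester.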